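Replacing 4-fluorophenyl with 2-chlorophenyl in the series

The compounds below may be only part of what the source reports. "The series", "measured", "known", "first", "only" and "open" are said of these compounds alone.

Three compounds have numbers in a functional assay on SGC-7901 cells (Homo sapiens) for antiproliferative activity, read by MTT assay, with a stated time of 48 h; a lower number here means a stronger inhibitor, a higher number a weaker inhibitor. Compound 1 `Cc1ccccc1-c1nnc(SCc2ccc(Cl)nc2)o1` gives 8.51 ug/mL. Compound 2 `COc1ccccc1-c1nnc(SCc2ccc(Cl)nc2)o1` gives 8.2 ug/mL. Compound 3 `Fc1ccc(-c2nnc(SCc3ccc(Cl)nc3)o2)cc1` gives 3.67 ug/mL, the lowest number of the three.

Compound 4 `Clc1ccc(CSc2nnc(-c3ccccc3Cl)o2)cn1` has no number yet. It carries 2-chlorophenyl in place of the 4-fluorophenyl of compound 3, on an aromatic carbon of the shared core (2-chlorophenyl in place of 4-fluorophenyl on an aromatic carbon).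

Within the data shown here, two measured steps bear on this change. Methoxy in place of methyl gives a 1.0-fold lower number from compound 1 to compound 2 (0.02 log units; within the scatter), so that swap offers no separation. The more relevant one is 4-fluorophenyl in place of 2-methylphenyl, which gives a 2.3-fold lower number from compound 1 to compound 3 (0.37 log units; beyond the scatter). Among the measured compounds shown here, no measured compound carries 2-chlorophenyl, so the nearest guide by name is the 2-methylphenyl of compound 1 at 8.51 ug/mL. Read in reverse, that step points toward a higher number for compound 4, of modest size and perhaps slightly smaller. This rests on a single step and remains uncertain.

The expected step is a 1.9-fold higher number from compound 3 to compound 4 (0.28 log units; within the scatter). The estimated value for compound 4 is 7 ug/mL, with an expected range of 3.5 ug/mL to 14 ug/mL.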

Compound 4, half-maximal inhibitory concentration: 13.5 ug/mL
For compound 4 the middle estimate is 1.9-fold (0.29 log units) below the measured one; the measured number falls inside the stated range.
By their numbers in this assay, from the lowest: compound 3; then compounds 2, 1 and 4 (each within the scatter of the next).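

In this assay the change on the aromatic carbon of the shared core gives a 3.7-fold higher number from compound 3 to compound 4 (0.57 log units; beyond the scatter), so 4-fluorophenyl now stands apart from 2-chlorophenyl as well as from the 2-methylphenyl of compound 1. Among the compounds with a group at the 2-position of the phenyl, chloro in place of methoxy gives a 1.6-fold higher number from compound 2 to compound 4 (0.22 log units; within the scatter) and chloro in place of methyl gives a 1.6-fold higher number from compound 1 to compound 4 (0.20 log units; within the scatter), so compounds 1, 2 and 4 cannot be told apart in this assay, and compound 3 alone lies beyond the scatter of all the others. Nothing available accounts for this separation.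

Compound 3 and compound 4 differ in both the halogen and its place on the phenyl, so the two remain tied together, and 2-fluorophenyl and 4-chlorophenyl would be the groups that could pull them apart. On these data alone, how a phenyl carrying an amine or a carboxylic acid would read also stays open.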